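Cytotoxicity notes: basic side chain swap in the amide series

The compounds below may be only part of what the source reports. "The series", "measured", "known", "first", "only" and "open" are said of these compounds alone.

Measured compounds:
compound 1 `CN(C)C1CCN(Cc2ccc(NC(=O)c3ccc(OCCCCl)c([N+](=O)[O-])c3)cc2C(F)(F)F)CC1`: 5500 nM
compound 2 `CC(C)Oc1ccc(C(=O)Nc2ccc(N(C)C)cc2)cc1[N+](=O)[O-]`: 50000 nM
compound 3 `CCC(=O)Nc1cc(C(=O)Nc2ccc(OC)cc2)ccc1OC`: 109000 nM

In a toxicity assay on Huh-7.5 cells (Homo sapiens) for inhibition, read by MTT assay, with a stated time of 96 h (a lower number here means that less compound is tolerated, a higher number that more compound is tolerated), compound 1 gives 5500 nM, the lowest number of the three. In this assay compound 2 gives 50000 nM and compound 3 gives 109000 nM. Both gaps to compound 1 lie beyond the scatter, so compound 1 is the least tolerated compound of the measured set. Among the measured compounds shown here, no pair of measured compounds differs in only one place, so nothing is known from these data about how a single change moves the number in this assay.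

Compound 4 `CN1CCN(Cc2ccc(NC(=O)c3ccc(OCCCCl)c([N+](=O)[O-])c3)cc2C(F)(F)F)CC1` is not yet measured. It differs from compound 1 in one place:
4-methylpiperazin-1-yl in place of 4-(dimethylamino)piperidin-1-yl on a saturated chain carbon bound to an aromatic carbon
The rest of the structure is shared with compound 1. For the measured compounds named here, the change swaps one basic six-membered ring for another of similar size at the same place, and no measured pair shows what such a swap does in this assay. The expected step of a 1.1-fold higher number from compound 1 to compound 4 (0.04 log units; within the scatter) is therefore small, with no direction beyond the scatter. For compound 4 the expected value in this assay is 6000 nM, with a range from 2500 nM to 15000 nM.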

Compound 4, half-maximal cytotoxic concentration: 6800 nM
The estimate for compound 4 lay 1.1-fold (0.05 log units) below the measured number; the measured number falls inside the stated range.
By their numbers in this assay, from the lowest: compounds 1 and 4 (each within the scatter of the next); then compound 2; then compound 3.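

Among the compounds shown here, with 4-methylpiperazin-1-yl in place of 4-(dimethylamino)piperidin-1-yl on a saturated chain carbon bound to an aromatic carbon, this assay gives a 1.2-fold higher number from compound 1 to compound 4 (0.09 log units; within the scatter) as the first reading of a single change. At this place, then, one six-membered non-aromatic ring can stand in for the other in this read-out without a shift beyond the scatter, although the entering group has fewer heavy atoms and carries both its nitrogens in the ring. No measured property of either group is at hand to account for this step.

The compounds shown leave open whether the same place accepts something other than these two rings, such as a morpholine ring, a carboxylic acid or an open-chain dimethylaminoethyl group. Also open, from the compounds shown here alone, is whether the number responds to a change elsewhere on the shared core, for example an amine in place of the nitro group or a shorter chain in place of the chlorine-bearing ether chain.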